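This account rests on a few compounds, and the source may have more. Where it says the series, first, only, none or still open, it means among the compounds named here.

Compound 1 `CCCCCCCCCCOc1ccc(-c2[nH]c3ccccc3c2C2=C(Br)C(=O)NC2=O)cc1` and compound 2 `O=C1NC(=O)C(c2c(-c3ccc(OCc4ccccc4)cc3)[nH]c3ccccc23)=C1Br` share the same core and differ only at the end of a group attached through an oxygen on an aromatic ring. In a physicochemical assay for lipophilicity (on this read-out lower numbers stand for lower lipophilicity and higher numbers for higher lipophilicity), compound 1 gives 5.94, while compound 2 gives 3.3. Exchanging the nonyl chain for a phenyl ring brought a drop of a number 2.64 log units lower from compound 1 to compound 2 (beyond the scatter), a large step well beyond the usual scatter. Going by the values given here, compound 2 therefore stands at the lower of the two numbers measured so far, with compound 1 the only neighbour and far above it.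

Compound 3 `O=C1NC(=O)C(c2c(-c3ccc(OCc4cccc5ccccc45)cc3)[nH]c3ccccc23)=C1Br` is the next member of the set. Compared with compound 2 it carries naphthalen-1-yl in place of phenyl on a saturated chain carbon bound to an oxygen on an aromatic ring. Among the compounds with values here, the only measured step that bears on this place, the one from compound 1 to compound 2, showed that shrinking the group attached there pushed this assay down sharply. Compound 3 goes the other way, enlarging the group at that place, so an increase is expected, though a smaller one than the earlier drop, since less is added than was removed. For compound 3 the expected rise is a number 1.20 log units higher from compound 2 to compound 3 (beyond the scatter), giving an estimate of 4.5, with a likely range from 4 to 5.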

Compound 3, partition coefficient: 3.76
Compound 3: the middle estimate sits 0.74 log units above what was measured; measured number outside the range, below it.
By their numbers in this assay, from the lowest: compound 2; then compound 3; then compound 1.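

In this assay, this place on a saturated chain carbon bound to an oxygen on an aromatic ring distinguishes not only a chain from an aromatic group, but also one aromatic group from another. Replacing phenyl, with its one six-membered aromatic ring of carbon only, by naphthalen-1-yl, with 2 such rings, gives a number 0.46 log units higher from compound 2 to compound 3 (beyond the scatter) as a modest step that is still beyond the scatter. The larger aromatic group recovers only part of the earlier drop, however, since exchanging nonyl for naphthalen-1-yl still leaves a number 2.18 log units lower from compound 1 to compound 3 (beyond the scatter) as a large step, so compound 1 stays well above both aromatic compounds. Nothing independent of these numbers is available to account for the size of either step.

The three compounds leave open how a shorter chain such as butyl, or a chain ending in an amine, would compare with the nonyl group of compound 1. They also leave open how this number would respond to a ring containing nitrogen, such as pyridin-3-yl, or to the isomeric naphthalen-2-yl group at the same place.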